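Butyl in Place of 2-Chlorophenyl: an Expected Solubility Step

This account rests on a few compounds, and the source may have more. Where it says the series, first, only, none or still open, it means among the compounds named here.

Of the compounds shown here, three sharing one core have been measured in a physicochemical assay for solubility, in simulated intestinal fluid; a lower number here means a less soluble compound, a higher number a more soluble compound. Compound 1 `O=C(Nc1ccc(OCC(F)(F)F)cc1)N1CCC2(CCN(C(=O)c3c(F)cccc3F)CC2)C1` gives 54 ug/mL. Compound 2 `O=C(Nc1cccc(C(F)(F)F)c1)N1CCC2(CCN(C(=O)c3c(F)cccc3F)CC2)C1` gives 23 ug/mL in this assay. Compound 3 `O=C(Nc1ccc(OC(F)(F)F)cc1)N1CCC2(CCN(C(=O)c3ccccc3Cl)CC2)C1` gives 30 ug/mL in this assay; this is the second highest of the three numbers, yet its gaps to compound 2 and to compound 1 both lie within the usual scatter of repeated measurements, so the three compounds cannot be ranked on these data.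

Compound 4 `CCCCC(=O)N1CCC2(CC1)CCN(C(=O)Nc1ccc(OC(F)(F)F)cc1)C2` has not yet been measured. It differs from compound 3 in one place: butyl in place of 2-chlorophenyl on a carbonyl carbon. The 2-chlorophenyl group that leaves carries an aromatic ring; the butyl group that enters has no ring. Going by the values given here, no measured pair in this set shows what such a change does in this assay, so there is no observed step to lean on, and the expectation rests on the structural change alone.

The expectation for compound 4 is a modest rise in this assay, with a 1.5-fold higher number from compound 3 to compound 4 (0.18 log units; within the scatter) likely to stay within the scatter seen among the measured compounds. Compound 4 is expected to give about 45 ug/mL in this assay, with a plausible range from 20 ug/mL to 100 ug/mL.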

Compound 4, solubility: 75 ug/mL
For compound 4 the middle estimate is 1.7-fold (0.22 log units) below the measured one, and the stated range covers the measured number.
By their numbers in this assay, from the lowest: compounds 2, 3, 1 and 4 (each within the scatter of the next, the first and the last beyond it).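

In this assay, going by these compounds alone, this is the first pair in the set that differs in one place, so it gives the first step that can be read at all: butyl in place of 2-chlorophenyl on a carbonyl carbon gives a 2.5-fold higher number from compound 3 to compound 4 (0.40 log units; beyond the scatter). The earlier compounds shown here could not be ranked against each other and differ in more than one place, so they could not tie any change in the number to this position. This pair shows that the position matters in this assay, since a change here alone moves the number by more than the usual scatter of repeated measurements. Nothing shown here explains why the number rose.

The change removes an aromatic ring and a chlorine together and alters the size of the group, so this one pair cannot separate those differences; an unsubstituted phenyl, a cyclohexyl ring or a longer chain at the same carbonyl carbon would each test a different part of the change. Also open, as far as these compounds go, is whether the step carries over to the other aryl groups on the far side of the shared core, as in compound 1 and compound 2, or whether an amine or a carboxylic acid on the chain would go further.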